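The source may report more compounds than this note shows. Statements on the series, on what has been measured and on what is new or still open speak of the compounds shown alone.

Compound 1 `CN(Cc1nc2cc(C(F)(F)F)ccc2nc1-c1ccccc1)c1ccc(Cl)cc1`, compound 2 `CN(Cc1nc2cc(C(F)(F)F)ccc2nc1-c1ccccc1)c1ccc(OC(F)(F)F)cc1` and compound 3 `CCN(Cc1nc2cc(C(F)(F)F)ccc2nc1-c1ccccc1)c1ccc(F)cc1` share one core and differ only at the amine side chain. In an assay on isolated protein for inhibition of Dihydrofolate reductase (Homo sapiens), read by spectrophotometry (a lower number here means a stronger inhibitor, a higher number a weaker inhibitor), compound 1 gives 5000 nM, compound 2 gives 3000 nM and compound 3 gives 3000 nM. Compound 3 thus stands level with compound 2 and within the scatter of compound 1; the three numbers do not separate. Compound 4 `CCN(Cc1nc2cc(C(F)(F)F)ccc2nc1-c1ccccc1)c1ccc(OC(F)(F)F)cc1` is not yet measured; from compound 3 the change is trifluoromethoxy in place of fluoro on an aromatic carbon. The closest measured step is a 1.7-fold lower number from compound 1 to compound 2 (0.22 log units; within the scatter), where trifluoromethoxy likewise entered an aromatic carbon, and a 1.7-fold lower number from compound 1 to compound 3 (0.22 log units; within the scatter) was of the same size. Both lie within the scatter, so in this assay a step of about a 1.2-fold lower number from compound 3 to compound 4 (0.08 log units; within the scatter) is expected, none beyond the scatter. Compound 4 is estimated at 2500 nM, expected between 1200 nM and 6000 nM.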

Compound 4, inhibition constant: 5000 nM
The estimate for compound 4 lay 2.0-fold (0.30 log units) below the measured number; low and high end bracket the measured number.
By their numbers in this assay, from the lowest: compounds 2, 3, 1 and 4 (each within the scatter of the next).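

Trifluoromethoxy in place of fluoro on this aromatic carbon gives a 1.7-fold higher number from compound 3 to compound 4 (0.22 log units; within the scatter) in this assay, and methyl in place of hydrogen on the saturated chain carbon gives a 1.7-fold higher number from compound 2 to compound 4 (0.22 log units; within the scatter) with the trifluoromethoxy group held fixed. Neither the change from 4-fluorophenyl to 4-(trifluoromethoxy)phenyl nor the added methyl moves the number beyond the scatter, so neither place separates these compounds. No evidence bearing on these steps is available. As far as these compounds go, whether an amine or a carboxylic acid on this aromatic carbon, or a longer chain in place of ethyl, would give a step beyond the scatter remains open.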